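A few compounds are considered here, and "the series" means these few. Any claim that something is new, unique, unknown or untested is made for them only; others in the source may bear on it.

Compound 1 `CCCc1nc2c(C)cc(-c3nc4ccccc4n3C)cc2n1S(=O)(=O)c1ccc(C)cc1` gives 20100 nM in a functional assay on HeLa cells (Homo sapiens) for cytotoxicity, read by MTT assay (on this read-out lower numbers stand for stronger inhibition and higher numbers for weaker inhibition), and compound 2 `CCCc1nc2c(C)cc(-c3nc4ccccc4n3C)cc2n1S(=O)(=O)c1ccc(Cl)cc1` gives 21400 nM. For compound 3 `CCCc1nc2c(C)cc(-c3nc4ccccc4n3C)cc2n1S(=O)(=O)c1ccccc1Cl` this assay reports only a limit, > 50000 nM. Compound 3 thus stands at the weak end of the numbers shown, sitting at the limit of > 50000 nM in this assay, at which 1 of the 3 values shown sits. The steps of an at least 2.4-fold higher number from compound 1 to compound 3 (0.39 log units; beyond the scatter) and an at least 2.3-fold higher number from compound 2 to compound 3 (0.36 log units; beyond the scatter) both run into that limit. Compound 4 `CCCc1nc2c(C)cc(-c3nc4ccccc4n3C)cc2n1S(=O)(=O)c1ccccc1Br` differs from compound 3 by bromo in place of chloro on an aromatic carbon. No measured step swaps one halogen for another on that ring, and nothing shown points to a shift beyond the scatter. Compound 4 is therefore expected to remain near the same limit, with an expected step that the limit leaves unreadable from compound 3 to compound 4. The estimate for compound 4 is 60000 nM, between 25000 nM and 150000 nM.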

Compound 4, half-maximal inhibitory concentration: > 50000 nM
Compound 4 ended at the assay's limit; the forecaster's own chance of this, stated with the estimate: 70%; the middle value is on the limit's open side.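

Compound 4 shows that the limit in this assay is not tied to chloro alone: with bromo in this place, ortho to a large group, the result is again a limit, and this now holds for two compounds: the limit of > 50000 nM in this assay, at which 2 of the 4 values shown sit. Compared with the compounds carrying their group on the 4-position of the ring, the change gives an at least 2.3-fold higher number from compound 2 to compound 4 (0.36 log units; beyond the scatter) and an at least 2.4-fold higher number from compound 1 to compound 4 (0.39 log units; beyond the scatter). The step between the two limits cannot be read, so chloro and bromo cannot be ranked here. On these data alone, it remains open whether an amine or a carboxylic acid in that same place would give a readable value.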